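Series notes: trifluoromethylphenyl amide of the shared core

The source may hold more compounds than are shown below. What is called first, only, known or untested is meant among the compounds shown, and "the series" means these compounds.

For the measured compounds named here, compound 1 `O=C(Nc1cc(-c2ccccc2)nn1-c1ccccc1)c1ccc(F)c(F)c1` is the one member of this set with a measured number: in an assay on CHO cells with metabotropic glutamate receptor 5 (Homo sapiens) as the target (a higher number here means that more compound is needed for the effect, a lower number that less compound is needed), compound 1 gives 10 nM. Compound 2 `O=C(Nc1cc(-c2ccccc2)nn1-c1ccccc1)c1ccccc1O` carries 2-hydroxyphenyl on the carbonyl carbon; in this assay compound 2 reaches only the limit > 10000 nM, so no number is known for it. Compound 3 `Cc1ccccc1C(=O)Nc1cc(-c2ccccc2)nn1-c1ccccc1` carries 2-methylphenyl there; in this assay compound 3 likewise gives only the limit > 10000 nM. Both steps from compound 1 are large: an at least 1000-fold higher number from compound 1 to compound 2 (3.00 log units; beyond the scatter) and an at least 1000-fold higher number from compound 1 to compound 3 (3.00 log units; beyond the scatter), with both partners sitting at the limit of > 10000 nM in this assay, at which 2 of the 3 values shown sit. The step between them, a step that the two limits leave unreadable from compound 2 to compound 3, cannot be read.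

Compound 4 `O=C(Nc1cc(-c2ccccc2)nn1-c1ccccc1)c1ccc(C(F)(F)F)cc1` is the next member. It differs from compound 1 in one place: 4-(trifluoromethyl)phenyl in place of 3,4-difluorophenyl on a carbonyl carbon. Neither measured step tests a 4-(trifluoromethyl)phenyl; both test 2-substituted phenyls and both wipe out activity, so the aryl on the carbonyl carbon is clearly sensitive to change, while fluorine-bearing aryl is the one thing known to work in compound 1. A moderate loss is therefore expected rather than a collapse: the step of a 4.0-fold higher number from compound 1 to compound 4 (0.60 log units; beyond the scatter) is the estimate, beyond the scatter but far from the limit. For compound 4 the expected value in this assay is 40 nM, within the range 8 nM to 400 nM.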

Compound 4, half-maximal effective concentration: 19 nM
Compound 4: middle estimate off by 2.1-fold (0.32 log units), on the high side, within the range that was stated.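

In this assay the place on the carbonyl carbon now holds a second aryl with a readable value, and replacing 3,4-difluorophenyl with 4-(trifluoromethyl)phenyl gives a 1.9-fold higher number from compound 1 to compound 4 (0.28 log units; within the scatter) and so does not separate the two groups. The collapse seen with 2-hydroxyphenyl and 2-methylphenyl therefore does not extend to every change of the aryl at this place, since the same new group gives an at least 520-fold lower number from compound 3 to compound 4 (2.72 log units; beyond the scatter) and an at least 520-fold lower number from compound 2 to compound 4 (2.72 log units; beyond the scatter). Both of these large steps are bounds only, and the step between compound 2 and compound 3 cannot be read, because each of those two compounds stops at a limit: the limit of > 10000 nM in this assay, at which 2 of the 4 values shown sit.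

Still open, going by these compounds, is whether fluorine is needed on this aryl at all, which plain phenyl, 4-methylphenyl or 4-methoxyphenyl would test. Also open, on these data alone, are whether 2-fluorophenyl would behave like 2-hydroxyphenyl and 2-methylphenyl, and whether anything other than an aryl, such as cyclohexyl or a longer alkyl chain, is accepted on the carbonyl carbon.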